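A few compounds are considered here, and "the series" means these few. Any claim that something is new, unique, unknown or untested is made for them only; others in the source may bear on it.

Of the compounds shown here, three have been tested so far in a functional assay for inhibition, read by spectrophotometry, with a stated time of 20 min, tested at 1 mg/mL; a higher number here means a stronger effect of the compound at the concentration tested, a lower number a weaker effect. Compound 1 `CCC(C)C(C(=O)Nc1ccc(C(C)=O)cc1)N(C(=O)c1ccccc1)S(=O)(=O)c1ccc([N+](=O)[O-])cc1` gives 28.6%. Compound 3 `CCC(C)C(C(=O)Nc1ccc(C(C)=O)cc1)N(C(=O)c1ccccc1)S(=O)(=O)c1ccccc1` shares the core of compound 1 and differs from it in one place, (hydrogen in place of nitro on an aromatic carbon); in this assay compound 3 gives 9.71%. That single change produced a number 18.9 percentage points lower from compound 1 to compound 3 (beyond the scatter). Compound 2 `CC(=O)c1ccc(NC(=O)C2CC(O)CN2S(=O)(=O)c2ccc([N+](=O)[O-])cc2)cc1` is built on a different core, and the difference between the two cores is not broken down here. In this assay compound 2 gives 43.2%, the highest of the three numbers, and its distance to compound 1 and to compound 3 lies beyond the scatter in both cases.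

Compound 4 `CC(=O)c1ccc(NC(=O)C2CC(O)CN2S(=O)(=O)c2ccccc2)cc1` has not yet been measured. It stands to compound 2 as compound 3 stands to compound 1: the change is hydrogen in place of nitro on an aromatic carbon, and the place of the change is described in the same words for both pairs, so this is the same change seen a second time. Because the earlier change gave a number 18.9 percentage points lower from compound 1 to compound 3 (beyond the scatter), a step of about the same size is expected now, a number 19.2 percentage points lower from compound 2 to compound 4 (beyond the scatter). That expectation rests on one earlier example only, so it carries real uncertainty. Compound 4 is therefore expected to give about 24%, with a likely range from 10% to 38%.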

Compound 4, a percentage reported as inhibition, at one concentration (the size of the read-out at that concentration, not a potency): 40.2%
Estimate against measurement, compound 4: 16.2 percentage points below; the whole stated range lies below it.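

In this assay, the change from 4-nitrophenyl to phenyl gave a number 3 percentage points lower from compound 2 to compound 4 (within the scatter), so on this core, removing the nitro group produced no difference that can be told apart from the ordinary spread of repeated measurements. The same change therefore did not carry over in size from one core to the other: the same change on two cores in this assay, a number 18.9 percentage points lower (beyond the scatter) from compound 1 to compound 3 and a number 3 percentage points lower (within the scatter) from compound 2 to compound 4, 15.9 percentage points apart, beyond the scatter of two such steps. This shows that a step seen on the core of compound 1 cannot simply be added to a value on the core of compound 2, but with a single pair on each core it does not show why the two cores differ, which part of them matters, or how a further core would respond.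

The compounds shown carry only nitro or hydrogen at this place on the ring, so it remains open whether another group there, such as an amine or a carboxylic acid, would give different steps on the two cores. From the compounds shown here alone, it also remains open whether a further core, for example one carrying a longer chain, would follow the pair of compound 1 and compound 3 or the pair of compound 2 and compound 4.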